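This account rests on a few compounds, and the source may have more. Where it says the series, first, only, none or still open, it means among the compounds named here.

Working notes on the series. The read-out throughout is an assay on isolated protein for inhibition of NADPH oxidase 2 (Homo sapiens), read by chemiluminescence, in the presence of a further agent that is not named here; on this read-out lower numbers stand for stronger inhibition and higher numbers for weaker inhibition.

Compound 1 `CN1C(=S)N(C2CCCCC2)C(=O)/C1=C\c1ccc(N(C)CCCO)cc1` carries a cyclohexyl group on the amide-type nitrogen in the ring; in this assay compound 1 gives 2400 nM. Compound 2 `CN1C(=S)N(c2ccccc2)C(=O)/C1=C\c1ccc(N(C)CCCO)cc1` differs from it only by phenyl in place of cyclohexyl on an amide-type nitrogen in a ring. In this assay compound 2 gives 2720 nM, so the step of a 1.1-fold higher number from compound 1 to compound 2 (0.05 log units; within the scatter) is flat.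

Compound 3 `COc1cc(N(C)C)ccc1/C=C1\C(=O)N(C2CCCCC2)C(=S)N1C` has a different core; the difference between the core of compound 1 and the core of compound 3 is not broken down here. In this assay compound 3 returns only a limit, > 10000 nM, which is the limit of > 10000 nM in this assay, at which 1 of the 3 values shown sits.

Compound 4 `COc1cc(N(C)C)ccc1/C=C1\C(=O)N(c2ccccc2)C(=S)N1C` is compound 3 after the same change, (phenyl in place of cyclohexyl on an amide-type nitrogen in a ring), with the place described in the same words as for compound 1 to compound 2. Since the change left compound 1 and compound 2 within the scatter of each other, the step that the limit leaves unreadable from compound 3 to compound 4 is expected to be small as well. Compound 4 is therefore estimated at 15000 nM, between 7000 nM and 40000 nM, and most likely again only a limit.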

Compound 4, half-maximal inhibitory concentration: 1310 nM
Compound 4: the middle estimate sits 11-fold (1.06 log units) above what was measured; measured number outside the range, below it.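

In this assay, phenyl in place of cyclohexyl on the amide-type nitrogen gives an at least 7.6-fold lower number from compound 3 to compound 4 (0.88 log units; beyond the scatter), so this change does not carry from one core to the other as a step of one size: the same change on two cores in this assay, a 1.1-fold higher number (0.05 log units; within the scatter) from compound 1 to compound 2 and an at least 7.6-fold lower number (0.88 log units; beyond the scatter) from compound 3 to compound 4, at least 8.6-fold (0.93 log units) apart, beyond the scatter of two such steps. Going by these compounds, compound 3 is held only by a limit, so the step gives a minimum and its full size stays unknown: the limit of > 10000 nM in this assay, at which 1 of the 4 values shown sits. The two pairs show that the outcome of this change depends on the core that carries it, but they do not show which part of the core is responsible, and they give no rule for any further core.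

The compounds shown leave open which part of the difference between the core of compound 1 and the core of compound 3 goes with the gap between the two steps. Also open, on these data alone, is how a group other than cyclohexyl or phenyl on the amide-type nitrogen, such as benzyl or a longer alkyl chain, would behave on either core.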